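This account rests on a few compounds, and the source may have more. Where it says the series, first, only, none or still open, it means among the compounds named here.

The compounds described here were tested in an assay on isolated protein for inhibition of Rho-associated protein kinase 2 (Homo sapiens), read by scintillation counting, radiometric assay and 33P incorporation, with a stated time of 40 min, in the presence of a further agent that is not named here; on this read-out higher numbers stand for weaker inhibition and lower numbers for stronger inhibition. Compound 1 `COc1ccc(OCC(=O)Nc2cccc(NC(=O)c3ccc(N(C)C)cc3)c2)cc1OC` returns only > 10000 nM, which is a limit of the assay and not a number. That reading sits at the limit of > 10000 nM in this assay, at which 1 of the 2 values shown sits. Compound 2 `COc1ccc(C(=O)Nc2cccc(NC(=O)COc3ccc4c(=O)ccoc4c3)c2)cc1` gives 7 nM in this assay, and this is the only number shown in the set; nothing else in the data places a second number beside it, so no measured step between compounds is available.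

Compound 3 `Cc1cc(C(=O)Nc2cccc(NC(=O)COc3ccc4c(=O)ccoc4c3)c2)no1` has not yet been measured in this assay. It differs from compound 2 in one place: 5-methyl-1,2-oxazol-3-yl in place of 4-methoxyphenyl on a carbonyl carbon. The (4-methoxyphenyl)carbonyl becomes a (5-methyl-1,2-oxazol-3-yl)carbonyl, while the rest of the shared core is unchanged.

For the measured compounds named here, with no measured step to lean on, the direction and size of the change can only be expected. The expected step is a 2.9-fold higher number from compound 2 to compound 3 (0.46 log units; beyond the scatter), a modest weakening that may sit at the edge of the usual scatter rather than clearly beyond it. Compound 3 is therefore estimated at 20 nM in this assay, with a range from 5 nM to 100 nM.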

Compound 3, half-maximal inhibitory concentration: 5 nM
Compound 3: middle estimate off by 4.0-fold (0.60 log units), on the high side; the range from low to high includes it.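

In this assay, the exchange of 4-methoxyphenyl for 5-methyl-1,2-oxazol-3-yl on a carbonyl carbon gives a 1.4-fold lower number from compound 2 to compound 3 (0.15 log units; within the scatter), so the two compounds cannot be told apart on this read-out. For the compounds shown here, this is the first measured step at this position, and it shows that a six-membered aromatic ring of carbon only and a five-membered aromatic ring with 2 hetero atoms can stand in this place with no separation beyond the scatter, even though the heavy-atom and acceptor counts differ. The data shown offer no measured explanation for this result.

The compounds shown leave open whether this position would also accept a group without an aromatic ring, such as cyclohexyl or piperidin-1-yl, or a phenyl ring carrying a carboxylic acid. Going by these compounds, compound 1 differs from compound 2 and compound 3 in more than one place, so the change that separates it from them also remains open, and the two measured groups alone do not define how much variation this position allows.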